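The compounds below may be only part of what the source reports. "The series", "measured", "known", "first", "only" and "open" are said of these compounds alone.

Of the compounds shown here, three built on one shared core have been measured in an assay on HEK293 cells for displacement of a labelled ligand from Melanocortin receptor 4 (Homo sapiens); on this read-out higher numbers stand for weaker inhibition and lower numbers for stronger inhibition. Compound 1 `CCC(C)CN[C@H](c1cc(C(F)(F)F)ccc1N1CCN(C(=O)CCc2ccc(Cl)cc2Cl)CC1)C(C)CC` gives 2800 nM. Compound 2 `CCC(C)[C@H](NC[C@H](C)N)c1cc(C(F)(F)F)ccc1N1CCN(C(=O)CCc2ccc(Cl)cc2Cl)CC1` gives 89 nM, and compound 3 `CCC(C)[C@H](NC[C@@H]1CCCN1)c1cc(C(F)(F)F)ccc1N1CCN(C(=O)CCc2ccc(Cl)cc2Cl)CC1` gives 64 nM. Compound 3 has the lowest of the three numbers, but its gap to compound 2 lies within the scatter, so those two cannot be told apart; its gap to compound 1 lies well beyond the scatter.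

Compound 4 `COCCN[C@@H](CC(C)C)c1cc(C(F)(F)F)ccc1N1CCN(C(=O)CCc2ccc(Cl)cc2Cl)CC1` differs from compound 3 by 1-((2-methoxyethyl)amino)-3-methylbutyl in place of 2-methyl-1-(((pyrrolidin-2-yl)methyl)amino)butyl on an aromatic carbon. The group that leaves carries a second nitrogen; the group that enters carries an oxygen in its place. The measured steps that bear on this change are a 44-fold lower number from compound 1 to compound 3 (1.64 log units; beyond the scatter) and a 31-fold lower number from compound 1 to compound 2 (1.50 log units; beyond the scatter), in which the side chain with a second nitrogen went with a far lower number than the side chain without one. Compound 4 lacks that second nitrogen and is expected to show a large step upward, a 23-fold higher number from compound 3 to compound 4 (1.37 log units; beyond the scatter). Compound 4 is estimated at 1500 nM, within a range from 400 nM to 6000 nM.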

Compound 4, inhibition constant: 620 nM
Compound 4: the middle estimate sits 2.4-fold (0.38 log units) above what was measured, and the stated range covers the measured number.
By their numbers in this assay, from the lowest: compounds 3 and 2 (each within the scatter of the next); then compound 4; then compound 1.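

In this assay a side chain without a second nitrogen can still give a clearly lower number, since the oxygen-bearing group gives a 4.5-fold lower number from compound 1 to compound 4 (0.65 log units; beyond the scatter) and so the second nitrogen is not the only thing that matters at this aromatic carbon. The nitrogen-bearing groups still go with the lower numbers, with a 9.7-fold higher number from compound 3 to compound 4 (0.99 log units; beyond the scatter) and a 7.0-fold higher number from compound 2 to compound 4 (0.84 log units; beyond the scatter) as the cost of this change. The entering group also carries a 3-methylbutyl chain where the other three compounds carry a 2-methylbutyl chain, so the oxygen and the chain change cannot be separated in these steps.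

No measurement is available that explains these differences. On these data alone, whether an amine in place of the methoxy group, on the same 3-methylbutyl chain, would reach the numbers of compound 2 and compound 3 remains open.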